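Bicyclic amine in place of pyrrolidinylmethylamino on a quinolone core

A few compounds are considered here, and "the series" means these few. Any claim that something is new, unique, unknown or untested is made for them only; others in the source may bear on it.

Three compounds share a quinolone-type core and were measured in an assay on isolated protein for inhibition of DNA topoisomerase 1 (Homo sapiens), with a stated time of 15 min; a higher number here means a weaker inhibitor, a lower number a stronger inhibitor. Compound 1 `COc1c(N2CC[C@@H](CN)C2)c(F)cc2c(=O)c(C(N)=O)cn(Cc3ccc(-c4ccccc4)cc3)c12` gives 184000 nM. Compound 2 `O=C(O)c1cn(Cc2ccc(-n3cccn3)cc2)c2cc(NC[C@H]3CCNC3)c(F)cc2c1=O` gives 187000 nM, the highest of the three numbers, though its gaps to compound 1 and to compound 3 both lie within the scatter. Going by the values given here, compound 3 `O=C(O)c1cn(Cc2ccc(-c3ccccc3)cc2)c2cc(NC[C@H]3CCNC3)c(F)cc2c1=O` gives 100000 nM; the only one-place step, a 1.9-fold lower number from compound 2 to compound 3 (0.27 log units; within the scatter), exchanges the aryl substituent and is itself within the scatter.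

Compound 4 `O=C(O)c1cn(Cc2ccc(-n3cccn3)cc2)c2cc(N3C[C@H]4CCNC[C@H]4C3)c(F)cc2c1=O` differs from compound 2 at the amine side chain: a group of 9 heavy atoms (7 carbon, 2 nitrogen; one five-membered non-aromatic ring with 1 hetero atom, one six-membered non-aromatic ring with 1 hetero atom) in place of a group of 7 heavy atoms (5 carbon, 2 nitrogen; one five-membered non-aromatic ring with 1 hetero atom), on an aromatic carbon. Among the compounds with values here, no measured step touches this position, and the aryl step from compound 2 to compound 3 stayed within the scatter, so nothing in the data points to a change in either direction. Compound 4 is therefore expected to stay close to compound 2, with the estimated step of no change at the digits printed from compound 2 to compound 4 (within the scatter) lying within the scatter. The estimate for compound 4 in this assay is 187000 nM, with a range from 60000 nM to 500000 nM.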

Compound 4, half-maximal inhibitory concentration: 31300 nM
For compound 4 the middle estimate is 6.0-fold (0.78 log units) above the measured one; measured number below the stated range.
By their numbers in this assay, from the lowest: compound 4; then compounds 3, 1 and 2 (each within the scatter of the next).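

In this assay, going by these compounds alone, the amine position on the aromatic carbon ortho to a fluoro group proved responsive, with a 6.0-fold lower number from compound 2 to compound 4 (0.78 log units; beyond the scatter), the only step in this set beyond the scatter, whereas the aryl exchange stayed within it. The entering group brings a second non-aromatic ring, a further defined stereocentre and fewer hydrogen-bond donors than ((pyrrolidin-3-yl)methyl)amino, and this single step cannot separate these differences. Nothing in the data gives a reason for the change.

From the compounds shown here alone, it remains open whether the same amine would have a comparable effect with the phenyl group of compound 3 in place of 1H-pyrazol-1-yl, or with the carboxamide of compound 1 in place of the carboxylic acid. Also open, going by these compounds, is how a methyl group on the ring nitrogen of the entering amine would change the number.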